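Swapping the group beside trifluoromethyl for 4-methylpiperazin-1-yl

The source may report more compounds than this note shows. Statements on the series, on what has been measured and on what is new or still open speak of the compounds shown alone.

In an ADME assay on BaF3 cells (Mus musculus) for inhibition, read by CellTiter-Glo, with a stated time of 72 h (a higher number here means a weaker inhibitor of growth, a lower number a stronger inhibitor of growth), compound 1 (`Cc1ccc(Nc2ncc3c(n2)N(C)C(=O)N(c2cc(NC(=O)c4ccc(C)c(C(F)(F)F)c4)ccc2C)C3)cn1`) gives 870 nM and compound 2 (`Cc1ccc(Nc2ncc3c(n2)N(C)C(=O)N(c2cc(NC(=O)c4ccc(-n5cccc5)c(C(F)(F)F)c4)ccc2C)C3)cn1`) gives 317 nM while compound 3 (`Cc1ccc(Nc2ncc3c(n2)N(C)C(=O)N(c2cc(NC(=O)c4ccc(CN5CCC(N(C)C)C5)c(C(F)(F)F)c4)ccc2C)C3)cn1`) gives 636 nM and so sits within the scatter of both others. Those two others do differ beyond the scatter, with a 2.7-fold lower number from compound 1 to compound 2 (0.44 log units; beyond the scatter) when 1H-pyrrol-1-yl replaces methyl.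

Compound 4 (`Cc1ccc(Nc2ncc3c(n2)N(C)C(=O)N(c2cc(NC(=O)c4ccc(N5CCN(C)CC5)c(C(F)(F)F)c4)ccc2C)C3)cn1`) is still unmeasured. The change 4-methylpiperazin-1-yl in place of (3-(dimethylamino)pyrrolidin-1-yl)methyl on an aromatic carbon puts 4-methylpiperazin-1-yl in place of (3-(dimethylamino)pyrrolidin-1-yl)methyl on an aromatic carbon, ortho to a trifluoromethyl group.

Earlier changes at this place bear on it. They gave a 1.4-fold lower number from compound 1 to compound 3 (0.14 log units; within the scatter) and a 2.0-fold higher number from compound 2 to compound 3 (0.30 log units; within the scatter) as steps inside the scatter, and the largest, a 2.7-fold lower number from compound 1 to compound 2 (0.44 log units; beyond the scatter), was only modest. Among the compounds with values here, no measured compound carries the new group, so no step beyond the scatter is expected in this assay in either direction. The expected outcome is a 1.3-fold lower number from compound 3 to compound 4 (0.10 log units; within the scatter) as an estimate. Compound 4 is estimated at 500 nM with 170 nM to 1400 nM as the expected range.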

Compound 4, concentration for 50% growth inhibition: 685 nM
For compound 4 the middle estimate is 1.4-fold (0.14 log units) below the measured one; low and high end bracket the measured number.
By their numbers in this assay, from the lowest: compounds 2, 3, 4 and 1 (each within the scatter of the next, the first and the last beyond it).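

In (this assay), 4-methylpiperazin-1-yl cannot be told apart from (3-(dimethylamino)pyrrolidin-1-yl)methyl (a 1.1-fold higher number from compound 3 to compound 4 (0.03 log units; within the scatter)) or from plain methyl (a 1.3-fold lower number from compound 1 to compound 4 (0.10 log units; within the scatter)), so this position, ortho to a trifluoromethyl group, accepts a second ring-bearing amine group of a different ring size with no step beyond the scatter. Within the data shown here, the only step beyond the scatter for the new group is the modest one against 1H-pyrrol-1-yl (a 2.2-fold higher number from compound 2 to compound 4 (0.33 log units; beyond the scatter)), which makes compound 2 the one compound set apart from compound 4. No measurement of any property of these groups is available to account for these numbers.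

From the compounds shown here alone, it remains open whether another aromatic ring, such as imidazol-1-yl, would give numbers like that of compound 2. Going by these compounds, it is also open whether a morpholin-4-yl ring, a carboxylic acid or a longer chain ending in an amine would move the number beyond the scatter.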